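Swapping Hydroxy for Methylsulfanyl on a Shared Core

The compounds below may be only part of what the source reports. "The series", "measured", "known", "first", "only" and "open" are said of these compounds alone.

Of the compounds shown here, three built on the same core have been tested. Compound 1 `CC(C)c1ncn2c(O)nncc12` carries an isopropyl group. In a functional assay for inhibition, with Homo sapiens as the target (a higher number here means a weaker inhibitor, a lower number a stronger inhibitor), compound 1 gives > 48000 nM, which is a limit of the assay rather than a number. Compound 2 `Cc1ncn2c(O)nncc12` carries a methyl group instead, and in this assay compound 2 gives > 48000 nM, again a limit. Compound 3 `CCCc1ncn2c(O)nncc12` carries a propyl group, and in this assay compound 3 gives > 48000 nM, once more a limit. Compound 3 therefore stands where the whole set stands: the limit of > 48000 nM in this assay, at which 3 of the 3 values shown sit.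

The steps among these three, a step that the two limits leave unreadable from compound 1 to compound 2, a step that the two limits leave unreadable from compound 1 to compound 3 and a step that the two limits leave unreadable from compound 2 to compound 3, concern only the alkyl group and cannot be sized, since every value is a limit.

Compound 4 `CCCc1ncn2c(SC)nncc12` differs from compound 3 in one place: methylsulfanyl in place of hydroxy on an aromatic carbon. Within the data shown here, none of the measured steps touches the hydroxy group, so they give no guidance on this change beyond showing that the core with a propyl group has not yet reached a measurable number. The step expected in this assay is an at least 1.2-fold lower number from compound 3 to compound 4 (0.07 log units; that floor lies within the scatter), with a limit again the most likely report. Compound 4 is thus estimated at 40000 nM, within 5000 nM to 200000 nM.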

Compound 4, half-maximal inhibitory concentration: > 48000 nM
Compound 4 gave a limit, no number; the forecaster's own chance of this, stated with the estimate: 70%; at least 1.2-fold (0.07 log units) between middle value and limit.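

In this assay, among these compounds, compound 4 gives > 48000 nM, a limit and not a number, so no step from compound 3 to compound 4 can be read. The compounds shown leave open how much the swap of hydroxy for methylsulfanyl changes the number, and whether any of these groups gives a measurable value, as all results stand at one point: the limit of > 48000 nM in this assay, at which 4 of the 4 values shown sit.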